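The compounds below may be only part of what the source reports. "The series", "measured", "known", "first", "only" and "open" are said of these compounds alone.

Going by the values given here, in a functional assay on MCF7 cells (Homo sapiens) for antiproliferative activity, read by MTT assay, with a stated time of 48 h (on this read-out higher numbers stand for weaker inhibition and lower numbers for stronger inhibition), compound 2 `N#CC1=C(N)Oc2c(c3nc4ccccc4nc3c3ccccc23)C12C(=O)N(Cc1cnnn1-c1ccc(Br)cc1)c1ccccc12` gives 36600 nM, the lowest of the two numbers measured so far. Its nearest neighbour is compound 1 `N#CC1=C(N)Oc2c(c3nc4ccccc4nc3c3ccccc23)C12C(=O)N(Cc1cnnn1-c1cccc(Cl)c1)c1ccccc12`, which gives 43600 nM; the step of a 1.2-fold lower number from compound 1 to compound 2 (0.08 log units; within the scatter) is a change of 4-bromophenyl in place of 3-chlorophenyl on an aromatic nitrogen. For compound 3 `N#CC1=C(N)Oc2c(c3nc4ccccc4nc3c3ccccc23)C12C(=O)N(Cc1cnnn1-c1ccc([N+](=O)[O-])cc1)c1ccccc12` the read-out is the limit of > 50000 nM in this assay, at which 1 of the 3 values shown sits, reported as > 50000 nM. The steps of an at least 1.1-fold higher number from compound 1 to compound 3 (0.05 log units; that floor lies within the scatter) and an at least 1.3-fold higher number from compound 2 to compound 3 (0.13 log units; that floor lies within the scatter) therefore also stay within the scatter.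

Compound 4 `Cc1cc(C)cc(-n2nncc2CN2C(=O)C3(C(C#N)=C(N)Oc4c3c3nc5ccccc5nc3c3ccccc43)c3ccccc32)c1` differs from compound 2 by 3,5-dimethylphenyl in place of 4-bromophenyl on an aromatic nitrogen. Every measured step exchanges the aryl group on that same aromatic nitrogen, or a substituent on it, and none moves the number beyond the scatter, so no step beyond the scatter is expected for compound 4 either. Compound 4 is therefore estimated at 40000 nM, with a range from 20000 nM to 80000 nM. This estimate means the expected step of a 1.1-fold higher number from compound 2 to compound 4 (0.04 log units; within the scatter), a number in the same region as compound 2, and its measurement is awaited.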

Compound 4, half-maximal inhibitory concentration: > 50000 nM
Compound 4: no number, only a limit (the forecaster's own chance of this, stated with the estimate: 35%); middle value at least 1.2-fold (0.09 log units) away from the limit.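

In this assay compound 4 gives > 50000 nM, which is a limit and not a number. The steps of an at least 1.3-fold higher number from compound 2 to compound 4 (0.13 log units; that floor lies within the scatter) and an at least 1.1-fold higher number from compound 1 to compound 4 (0.05 log units; that floor lies within the scatter) have floors within the scatter, so the 3,5-dimethylphenyl group, which carries only carbon in place of the bromine of 4-bromophenyl, still gives no step beyond the scatter at this aromatic nitrogen, while the step between compound 3 and compound 4 cannot be read. Compound 3 and compound 4, with their different aryl groups, now stand at one and the same limit, and the read-out gives no order between them: the limit of > 50000 nM in this assay, at which 2 of the 4 values shown sit.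

From the compounds shown here alone, how far compound 4 actually lies from compound 2 stays open. Also open, going by these compounds, is whether a different group on this nitrogen, such as an aminophenyl, a carboxylic acid on the phenyl ring, or a longer alkyl chain in place of the aryl ring, would give a step beyond the scatter.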